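Methoxy addition on a second core: an expectation

The source may report more compounds than this note shows. Statements on the series, on what has been measured and on what is new or still open speak of the compounds shown alone.

Measured compounds in a functional assay on MCF7 cells (Homo sapiens) for antiproliferative activity, read by MTT assay, with a stated time of 48 h; on this read-out higher numbers stand for weaker inhibition and lower numbers for stronger inhibition:
compound 1 `COc1cc(/C=N/c2c(C#N)ncn2Cc2ccc(F)cc2)cc(OC)c1OC` gives 9040 nM
compound 2 `COc1ccc(/C=N/c2c(C#N)ncn2Cc2ccc(F)cc2)cc1OC` gives 11100 nM
compound 3 `COc1ccc(C2N=C(C(N)=O)c3ncn(-c4ccc(F)cc4)c3N2)cc1` gives 3990 nM

Compound 1 and compound 2 share one core and differ in a single place. The change is methoxy in place of hydrogen on an aromatic carbon. In this assay it made a step of a 1.2-fold lower number from compound 2 to compound 1 (0.09 log units; within the scatter), so the two values cannot be ranked against each other.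

Compound 3 carries a different core. How its core differs from that of compound 2 is not broken down here. In this assay compound 3 gives the lowest of the three numbers, and its steps to compound 1 and to compound 2 are both beyond the scatter.

Compound 4 `COc1ccc(C2N=C(C(N)=O)c3ncn(-c4ccc(F)cc4)c3N2)cc1OC` is not yet measured. It is derived from compound 3 by methoxy in place of hydrogen on an aromatic carbon. Among the measured compounds shown here, this is the same kind of change as the one from compound 2 to compound 1, though not the same: around the place in compound 1 the entering methoxy is also meta to a methoxy group, whereas in compound 4 it is not.

For the measured compounds named here, the only guide to the size of the step is the earlier one on the first core. Because that step was a 1.2-fold lower number from compound 2 to compound 1 (0.09 log units; within the scatter), the step from compound 3 to compound 4 is expected to be small as well, estimated as a 1.1-fold lower number from compound 3 to compound 4 (0.06 log units; within the scatter). The estimate for compound 4 in this assay is therefore 3500 nM, with a range from 1500 nM to 8000 nM; it rests on one pair only, and the second core could respond differently.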

Compound 4, half-maximal inhibitory concentration: 5710 nM
Compound 4: middle estimate off by 1.6-fold (0.21 log units), on the low side; the measured number falls inside the stated range.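

In this assay, methoxy in place of hydrogen on an aromatic carbon gives a step of a 1.4-fold higher number from compound 3 to compound 4 (0.16 log units; within the scatter), so the two values on this core cannot be ranked against each other. Set beside the earlier step, the change shows no measurable dependence on the core, and the opposite directions of the two steps carry no weight: the same change on two cores in this assay, a 1.2-fold lower number (0.09 log units; within the scatter) from compound 2 to compound 1 and a 1.4-fold higher number (0.16 log units; within the scatter) from compound 3 to compound 4, 1.8-fold (0.24 log units) apart, within the scatter of two such steps This shows only that, on these two pairs in this one assay, adding the methoxy leaves the number within the scatter; it does not show that the change would behave the same way on a further core, or at another place on the ring than the one in compound 4, ortho to a methoxy group and meta to a large group.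

The compounds shown leave open whether another group at this place, such as a hydroxy group, an amine, a carboxylic acid or a longer chain such as propoxy, would give a step beyond the scatter on either core. They also leave open which part of the structural difference between compound 2 and compound 3 goes with the lower number of compound 3.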